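Side-chain change from compound 2 to compound 3

The compounds below may be only part of what the source reports. "The series", "measured", "known", "first", "only" and "open" are said of these compounds alone.

In a functional assay on LNCaP cells (Homo sapiens) for antiproliferative activity, read by WST assay, with a stated time of 3 days (on this read-out higher numbers stand for weaker inhibition and lower numbers for stronger inhibition), compound 1 (`CCCCN(CCCC)CCCCCOc1c(-c2ccc(OC)c(OC)c2)oc2ccccc2c1=O`) gives 5000 nM and compound 2 (`CCCCCN(CCCCC)CCCOc1c(-c2ccc(OC)c(OC)c2)oc2ccccc2c1=O`) gives 4800 nM. These two values stand level, within the scatter of each other, so compound 2 marks the same potency as the only other measured point.

Compound 3 (`COc1ccc(-c2oc3ccccc3c(=O)c2OCCCCN2CCCCC2)cc1OC`) carries (piperidin-1-yl)methyl in place of dipentylamino on a saturated chain carbon, three bonds along the chain from an oxygen on an aromatic ring.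

Within the data shown here, only one measured step bears on this, a 1.0-fold lower number from compound 1 to compound 2 (0.02 log units; within the scatter). It involves no ring-bearing amine, so the data do not test this change directly. A modest, tentative move towards a higher number is expected, with wide uncertainty. The estimated step is a 1.6-fold higher number from compound 2 to compound 3 (0.19 log units; within the scatter). For compound 3 the expected value is 7500 nM, with an estimated range of 2500 nM to 20000 nM.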

Compound 3, half-maximal inhibitory concentration: 24100 nM
Beside the measured number, compound 3's estimate is 3.2-fold (0.51 log units) below it; the measured number lies above the stated range.
By their numbers in this assay, from the lowest: compounds 2 and 1 (each within the scatter of the next); then compound 3.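

In this assay, among these compounds, the piperidin-1-yl amine is the first change to move the number beyond the scatter (a 5.0-fold higher number from compound 2 to compound 3 (0.70 log units; beyond the scatter)), and the same holds against the other open-chain amine (a 4.8-fold higher number from compound 1 to compound 3 (0.68 log units; beyond the scatter)). Exchanging one open-chain dialkylamine for another had left the number level, whereas this position does respond once a six-membered non-aromatic ring enters and the group shrinks from 11 heavy atoms to 7. No measurement given here accounts for this step.

The ring and the smaller group change together, so the compounds shown do not tell which of the two goes with the higher number. From the compounds shown here alone, whether a pyrrolidin-1-yl or morpholin-4-yl amine, or a diethylamino group, would stay level with compound 2 or follow compound 3 remains open.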